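From compound 3 to compound 4: a chloro step

The compounds below may be only part of what the source reports. "The series", "measured", "known", "first", "only" and "open" are said of these compounds alone.

Compound 1 `CCOC(=O)c1nn(-c2ccccc2)c(-c2ccc(C)cc2)c1CNC(C)(C)C`, compound 2 `CC(C)(C)NCc1c(C(=O)O)nn(-c2ccccc2)c1-c1ccc(Br)cc1` and compound 3 `Cc1ccc(-c2c(CNC(C)(C)C)c(C(=O)O)nn2-c2ccccc2)cc1` share a core and all have readings in a functional assay on HT-29 cells (Homo sapiens) for inhibition, read by sulforhodamine B assay, with a stated time of 48 h; on this read-out lower numbers stand for stronger inhibition of growth and higher numbers for weaker inhibition of growth. In this assay compound 1 gives 68100 nM; > 585000 nM (2 entries). Compound 2 gives > 585000 nM, which is a limit. Compound 3 gives > 688000 nM, which is also a limit, so compound 3 stands without a number.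

Compound 4 `Cc1ccc(-c2c(CNC(C)(C)C)c(C(=O)O)nn2-c2ccc(Cl)cc2)cc1` differs from compound 3 by chloro in place of hydrogen on an aromatic carbon, para to a large group, so that phenyl becomes 4-chlorophenyl.

Among the measured compounds shown here, the only measured single-place change is a step that the two limits leave unreadable from compound 2 to compound 3, a swap of methyl for bromo. It gives no size to carry over, so no shift beyond the scatter is expected in this assay, in either direction. The expected change is an at least 1.1-fold lower number from compound 3 to compound 4 (0.05 log units; that floor lies within the scatter).

For compound 4 the estimated value is 600000 nM, with an expected range of 150000 nM to 900000 nM, and a report as a limit alone is the likelier outcome.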

Compound 4, concentration for 50% growth inhibition: > 629000 nM
Compound 4: no number, only a limit; the forecaster's own chance of this, stated with the estimate: 80%; at least 1.0-fold (0.02 log units) between middle value and limit.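

No new step can be read: compound 3 and compound 4 both stand only as limits in this assay, so the step between them has no size. The compounds shown leave open whether chloro in place of hydrogen changes growth inhibition at all.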